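A few compounds are considered here, and "the series" means these few. Any claim that something is new, unique, unknown or untested is made for them only; others in the source may bear on it.

Among the three measured compounds, compound 1 `Cc1nccc(N2c3ccc(C4(NC(=O)c5ccc(F)cc5)CC4)cc3[C@H]3CC[C@H]32)n1` gives the lowest number in an assay on HeLa cells for inhibition of Indoleamine 2,3-dioxygenase 1 (Homo sapiens) (on this read-out higher numbers stand for weaker inhibition and lower numbers for stronger inhibition), with 3.8 nM. Compound 2 `Cc1nccc(N2CCc3nc(C4(C(=O)Nc5ccc(Cl)cc5)CCC4)ccc32)n1` gives 12.5 nM in this assay, and compound 3 `Cc1nccc(N2CCc3nc(C4(C(=O)Nc5ccc(F)cc5)CCC4)ccc32)n1` gives 21 nM. Within the data shown here, the only measured step that changes one place is a 1.7-fold higher number from compound 2 to compound 3 (0.23 log units; within the scatter), a fluoro in place of chloro on an aromatic carbon. Compound 4 `Cc1nccc(N2c3ccc(C4(NC(=O)c5ccc(F)cc5)CC4)cc3[C@@H]3CC[C@@H]32)n1` differs from compound 1 in that (the two compounds have the same atoms and bonds and differ only in configuration as drawn: 2 of 2 stereo elements differ (all stereocentres are inverted: mirror images); a stereocentre at a saturated ring carbon is drawn R in compound 1 and S in compound 4; a stereocentre at a saturated ring carbon is drawn R in compound 1 and S in compound 4). Among the measured compounds shown here, no measured step concerns a change of configuration, so the step from compound 2 to compound 3 does not bear on it, and nothing here shows how far the mirror image moves the number. Pairs of mirror images in this kind of assay often differ widely, so the number for compound 4 is expected to be higher than that of compound 1, with considerable uncertainty in both directions. Compound 4 is estimated at 40 nM, within 4 nM to 600 nM, a change of an 11-fold higher number from compound 1 to compound 4 (1.02 log units; beyond the scatter).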

Compound 4, half-maximal inhibitory concentration: 5 nM
Estimate against measurement, compound 4: 8.0-fold (0.90 log units) above; low and high end bracket the measured number.
By their numbers in this assay, from the lowest: compounds 1 and 4 (each within the scatter of the next); then compounds 2 and 3 (each within the scatter of the next).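

In this assay, inverting both stereocentres at the saturated ring carbons gives a 1.3-fold higher number from compound 1 to compound 4 (0.12 log units; within the scatter), so on this read-out the two mirror images cannot be told apart. Among these compounds, the earlier step concerned only a halogen on an aromatic carbon, so this is the first evidence on configuration, and for this pair the configuration as drawn makes no difference beyond the scatter. The comparison isolates configuration and nothing else: the fact that compounds 1 and 4 differ only in the configuration as drawn.

The compounds shown leave open whether a compound with only one of the two stereocentres inverted would fall in the same range, since mirror images invert both together. They also leave open whether the same insensitivity to configuration would hold if a nitrile or a methoxy group replaced the fluoro group on the aromatic ring of compound 1.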